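Replacing the 4-cyanophenyl of compound 1 with pyridin-2-yl

The source may report more compounds than this note shows. Statements on the series, on what has been measured and on what is new or still open speak of the compounds shown alone.

The series shares one core, with compound 1 `CN1C[C@H](C(=O)Nc2ccc(C#N)cc2)[C@@H](c2ccc(/C=C/C(=O)Nc3ccccc3N)cc2)C1` carrying a 4-cyanophenyl on the amide-type nitrogen. In an in vitro ADME assay on microsomes from liver (Homo sapiens) for pharmacokinetics, read by LC-MS, with a stated time of 10 min, tested at 1 uM (a higher number here means faster removal of the compound, a lower number slower removal), compound 1 gives 1 mL/min/kg, the lowest of the three numbers. Compound 2 `CN1C[C@H](C(=O)Nc2ccccc2F)[C@@H](c2ccc(/C=C/C(=O)Nc3ccccc3N)cc2)C1` gives 10 mL/min/kg and compound 3 `CN1C[C@H](C(=O)Nc2ccc(F)c(Cl)c2)[C@@H](c2ccc(/C=C/C(=O)Nc3ccccc3N)cc2)C1` gives 15 mL/min/kg in this assay; the rise is a 10-fold higher number from compound 1 to compound 2 (1.00 log units; beyond the scatter) and a 15-fold higher number from compound 1 to compound 3 (1.18 log units; beyond the scatter), while the pair a 1.5-fold higher number from compound 2 to compound 3 (0.18 log units; within the scatter) separates little. Among the compounds with values here, compound 4 `CN1C[C@H](C(=O)Nc2ccccn2)[C@@H](c2ccc(/C=C/C(=O)Nc3ccccc3N)cc2)C1` differs from compound 1 as follows: pyridin-2-yl in place of 4-cyanophenyl on an amide-type nitrogen No measured step covers this exact change; the two known replacements of the same group both raised the number markedly. Compound 4 is therefore expected to show a 5.0-fold higher number from compound 1 to compound 4 (0.70 log units; beyond the scatter), estimated at 5 mL/min/kg with a likely range of 1.5 mL/min/kg to 20 mL/min/kg.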

Compound 4, clearance: 8 mL/min/kg
For compound 4 the middle estimate is 1.6-fold (0.20 log units) below the measured one, and the stated range covers the measured number.
By their numbers in this assay, from the lowest: compound 1; then compounds 4, 2 and 3 (each within the scatter of the next).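

In this assay, pyridin-2-yl, the only replacement shown with a hetero atom in the ring, also fails to keep the number of the 4-cyanophenyl compound (an 8.0-fold higher number from compound 1 to compound 4 (0.90 log units; beyond the scatter)). Compound 4 cannot be told apart from the two halogen-bearing phenyl compounds (a 1.9-fold lower number from compound 3 to compound 4 (0.27 log units; within the scatter); a 1.3-fold lower number from compound 2 to compound 4 (0.10 log units; within the scatter)), so among these four compounds only compound 1 stands apart. Nothing available explains this separation.

From the compounds shown here alone, it remains open whether the low number depends on the nitrile itself or on the whole 4-cyanophenyl group. A pyridin-2-yl carrying a nitrile, or a phenyl carrying a carboxylic acid or an amine, would test this further.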